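A few compounds are considered here, and "the series" means these few. Any claim that something is new, unique, unknown or untested is made for them only; others in the source may bear on it.

Within the data shown here, in an ADME assay on MT4 cells (Homo sapiens) for cytotoxicity, read by MTT assay, with a stated time of 5 days (on this read-out lower numbers stand for higher toxicity in this test and higher numbers for lower toxicity in this test), compound 1 `Cc1cc(C)cc(S(=O)(=O)c2c(C(=O)N[C@@H]3CCN(CC(N)=O)C3)[nH]c3ccc(Cl)cc23)c1` gives 31000 nM and compound 2 `Cc1cc(C)cc(S(=O)(=O)c2c(C(=O)NC3CN(Cc4n[nH]c(=O)n4C)C3)[nH]c3ccc(Cl)cc23)c1` gives 25200 nM as its read-out, so compound 2 stands level with the only other compound measured so far. Compound 3 `Cc1cc(C)cc(S(=O)(=O)c2c(C(=O)NS(=O)(=O)c3ccc(F)cc3F)[nH]c3ccc(Cl)cc23)c1` keeps the shared core and differs from compound 2 on the amide-type nitrogen, where the change is a group of 11 heavy atoms (6 carbon, 2 oxygen, 2 fluorine, 1 sulfur; one six-membered aromatic ring of carbon only) in place of a group of 12 heavy atoms (7 carbon, 4 nitrogen, 1 oxygen; one four-membered non-aromatic ring with 1 hetero atom, one five-membered aromatic ring with 3 hetero atoms), on an amide-type nitrogen and the entering group is (2,4-difluorophenyl)sulfonyl. Among the measured compounds shown here, one measured step bears on this change, a 1.2-fold lower number from compound 1 to compound 2 (0.09 log units; within the scatter) on that same nitrogen, and it stays within the scatter. For the measured compounds named here, that step is thin guidance, since both of its groups carry a non-aromatic ring with a hetero atom and no measured compound has a sulfonyl group at this place. A shift beyond the scatter in this assay is therefore not expected in either direction, although the range has to stay wide. The expected change is a 1.3-fold lower number from compound 2 to compound 3 (0.10 log units; within the scatter) and it would lie within the scatter. In this assay the estimated value for compound 3 is 20000 nM with an expected range from 6000 nM to 60000 nM around it.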

Compound 3, half-maximal cytotoxic concentration: 121000 nM
Compound 3: middle estimate off by 6.1-fold (0.78 log units), on the low side; measured number above the stated range.
By their numbers in this assay, from the lowest: compounds 2 and 1 (each within the scatter of the next); then compound 3.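

In this assay, the amide-type nitrogen now proves able to move the read-out beyond the scatter, with both new steps pointing the same way (a 4.8-fold higher number from compound 2 to compound 3 (0.68 log units; beyond the scatter); a 3.9-fold higher number from compound 1 to compound 3 (0.59 log units; beyond the scatter)). Among these compounds, the one earlier step on this nitrogen (a 1.2-fold lower number from compound 1 to compound 2 (0.09 log units; within the scatter)) stayed within the scatter, although its two groups differ in ring size and in the presence of a five-membered aromatic ring, so that exchange left the number where it was while the entry of (2,4-difluorophenyl)sulfonyl did not. This group is the only one shown here on that nitrogen with a sulfonyl unit and a six-membered aromatic ring of carbon only, and nothing measured accounts for the shift.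

The compounds shown leave open whether the sulfonyl unit or the two fluorines on the aromatic ring carry the step; an unsubstituted phenylsulfonyl or a methylsulfonyl group on the same nitrogen would bear on that. From the compounds shown here alone, it also remains open how an amine or a carboxylic acid at the end of a short chain on this nitrogen would read in this test.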